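This account rests on a few compounds, and the source may have more. Where it says the series, first, only, none or still open, it means among the compounds named here.

In an assay for inhibition of high affinity nerve growth factor receptor (Homo sapiens), read by HTRF, with a stated time of 30 min, in the presence of a further agent that is not named here (on this read-out lower numbers stand for stronger inhibition and higher numbers for weaker inhibition), compound 1 `Cc1ccc2nc(NCc3ccc(F)cc3F)nc(Nc3cc(C)[nH]n3)c2c1` gives 110 nM. Compound 2 `Cc1cc(Nc2nc(NCc3ccc(F)cc3F)nc3ccc(C(F)(F)F)cc23)n[nH]1` differs from it by one change, (trifluoromethyl in place of methyl on an aromatic carbon), and in this assay compound 2 gives 370 nM, so that a 3.4-fold higher number from compound 1 to compound 2 (0.53 log units; beyond the scatter). Compound 3 `Cc1ccc2c(Nc3cc(C)[nH]n3)nc(NCc3ccc(F)cc3F)nc2c1` has the same atoms as compound 1 joined differently; how the two cores differ is not broken down here. In this assay compound 3 gives 27 nM, the lowest of the three numbers. Compound 4 `Cc1cc(Nc2nc(NCc3ccc(F)cc3F)nc3cc(C(F)(F)F)ccc23)n[nH]1` has not yet been measured; it differs from compound 3 by trifluoromethyl in place of methyl on an aromatic carbon, the same change as from compound 1 to compound 2, at a place described in identical words. Going by the values given here, the expected step is a 3.3-fold higher number from compound 3 to compound 4 (0.52 log units; beyond the scatter), because a 3.4-fold higher number from compound 1 to compound 2 (0.53 log units; beyond the scatter) is the only guide available. Compound 4 is therefore estimated at 90 nM, likely between 40 nM and 200 nM.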

Compound 4, half-maximal inhibitory concentration: 57 nM
For compound 4 the middle estimate is 1.6-fold (0.20 log units) above the measured one; the measured number falls inside the stated range.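

In this assay, trifluoromethyl in place of methyl on an aromatic carbon gives a 2.1-fold higher number from compound 3 to compound 4 (0.32 log units; beyond the scatter) and so raises the number on this core too. Set beside the earlier step, the size of the change cannot be told apart between the two cores: the same change on two cores in this assay, a 3.4-fold higher number (0.53 log units; beyond the scatter) from compound 1 to compound 2 and a 2.1-fold higher number (0.32 log units; beyond the scatter) from compound 3 to compound 4, 1.6-fold (0.20 log units) apart, within the scatter of two such steps. Going by these compounds alone, this rests on only two pairs in a single assay, so it supports carrying the change between these two cores but does not show that it would hold on any other core, or why the number rises.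

Going by these compounds, what a chlorine atom, an amine or a carboxylic acid at this place would give remains open. So does whether a longer chain there would follow the same direction.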